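The source may report more compounds than this note shows. Statements on the series, on what has been measured and on what is new or still open speak of the compounds shown alone.

Compound 1, `COc1cc(-c2ccnc3cc(-c4ccc(C(C)(C)C)cc4)nn23)cc(OC)c1OC`, carries a tert-butyl group on the outer phenyl ring. In a functional assay on A549 cells (Homo sapiens) for inhibition, read by CCK-8 assay, with a stated time of 48 h (a lower number here means a stronger inhibitor, a higher number a weaker inhibitor), compound 1 gives only a limit of the assay, > 10000 nM. Compound 2, `COc1ccc(-c2cc3nccc(-c4cc(OC)c(OC)c(OC)c4)n3n2)cc1`, has a methoxy group in that spot; in this assay compound 2 gives 376 nM. Compound 3, `CCOC(=O)c1ccc(-c2cc3nccc(-c4cc(OC)c(OC)c(OC)c4)n3n2)cc1`, carries an ethoxycarbonyl group there. In this assay compound 3 gives a limit as well, > 10000 nM. Two of the three compounds sit at that limit, (the limit of > 10000 nM in this assay, at which 2 of the 3 values shown sit), so compound 1 can only be placed among the weakest of the set, with no number of its own.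

Compound 4, `C=Cc1ccc(-c2cc3nccc(-c4cc(OC)c(OC)c(OC)c4)n3n2)cc1`, is the next member: vinyl in place of tert-butyl on an aromatic carbon. Among the compounds with values here, the steps that bear on it are an at least 26-fold lower number from compound 1 to compound 2 (1.42 log units; beyond the scatter) and an at least 26-fold higher number from compound 2 to compound 3 (1.42 log units; beyond the scatter), while the step from compound 1 to compound 3 cannot be read. A small substituent gave a number and a bulky or ester-bearing one gave a limit, so a vinyl group is expected to land between these outcomes; the estimate for compound 4 is 3000 nM, within 500 nM to 15000 nM, which would be an expected step of an at least 3.3-fold lower number from compound 1 to compound 4 (0.52 log units; beyond the scatter).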

Compound 4, half-maximal inhibitory concentration: 1030 nM
Estimate against measurement, compound 4: 2.9-fold (0.46 log units) above; measured number inside the range.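

In this assay, the vinyl group shows that an all-carbon group at this position can still give a real number rather than a limit, with an at least 9.7-fold lower number from compound 1 to compound 4 (0.98 log units; beyond the scatter) and an at least 9.7-fold lower number from compound 3 to compound 4 (0.98 log units; beyond the scatter). The two groups that give numbers can also now be compared, and methoxy keeps the edge, with a 2.7-fold higher number from compound 2 to compound 4 (0.44 log units; beyond the scatter). The first two steps give only a minimum size and not an exact one, because compound 1 and compound 3 each rest on a limit of the assay: the limit of > 10000 nM in this assay, at which 2 of the 4 values shown sit.

On these data alone, it remains open whether an ethyl group, which would keep the two carbons of vinyl but lose the double bond, would give a similar number. Also open, as far as these compounds go, is how an amine, a carboxylic acid or a longer chain would behave at this position.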